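The compounds below may be only part of what the source reports. "The series", "measured", "known", "first", "only" and "open" are said of these compounds alone.

Working notes on the series in a functional assay for inhibition, with Rattus norvegicus as the target; a lower number here means a stronger inhibitor, a higher number a weaker inhibitor. Of the compounds shown here, three have been measured, and no two differ in only one place. Compound 1 `CCOC(=O)c1c(CC)c(OC(C)=O)c2ccccc2c1OC` gives 1160 nM, compound 2 `COc1cc(-c2ccccc2)c(OC(C)=O)c2ccn(C)c12` gives 3860 nM, and compound 3 `CCCCc1c(C)c(OC)c2c(ccn2C)c1OC(C)=O` gives 760 nM. Compound 3 lies within the scatter of compound 1, while compound 2 stands beyond the scatter from compound 3, as the weaker inhibitor.

Compound 4 `CCCCc1cc(OC)c2c(ccn2C)c1OC(C)=O` is the next to read. It departs from compound 3 by hydrogen in place of methyl on an aromatic carbon, ortho to a butyl group and ortho to a methoxy group. The series holds no direct measure of this change, so the expectation is loose. The butyl group and the acetoxy group both stay in place, and the loss is a single methyl, so only a modest shift is expected. The expected change is a 1.4-fold higher number from compound 3 to compound 4 (0.16 log units; within the scatter), towards a slightly weaker inhibitor and within the scatter. For compound 4 the estimated value is 1100 nM, with an expected range of 450 nM to 2700 nM.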

Compound 4, half-maximal inhibitory concentration: 720 nM
For compound 4 the middle estimate is 1.5-fold (0.18 log units) above the measured one, and the stated range covers the measured number.
By their numbers in this assay, from the lowest: compounds 4, 3 and 1 (each within the scatter of the next); then compound 2.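

In this assay the step for hydrogen in place of methyl, ortho to a butyl group and ortho to a methoxy group, is a 1.1-fold lower number from compound 3 to compound 4 (0.02 log units; within the scatter) and so shows that the methyl on this aromatic carbon is not needed for a number in this range. The step for butyl in place of phenyl on an aromatic carbon is a 5.4-fold lower number from compound 2 to compound 4 (0.73 log units; beyond the scatter) and gives the series its first single-place difference beyond the scatter, with the butyl compound as the stronger inhibitor. No supporting data bear on the cause of either step.

On these data alone, whether a larger group on the methyl-bearing carbon, such as ethyl or a chlorine atom, fits the same range remains open. Also open, as far as these compounds go, is how a shorter propyl chain, a longer hexyl chain or an amine would read in place of the butyl group.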